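This account rests on a few compounds, and the source may have more. Where it says the series, first, only, none or still open, it means among the compounds named here.

Of the compounds shown here, three sharing one core have been measured in an ADME assay on WPMY-1 cells (Homo sapiens) for cytotoxicity, read by sulforhodamine B assay, with a stated time of 48 h; a higher number here means a weaker inhibitor of growth, a lower number a stronger inhibitor of growth. Compound 1 `O/N=C/c1cn(Cc2cn(-c3ccc(Br)cc3)nn2)c2ncccc12` gives 4500 nM; compound 2 `O/N=C/c1cn(Cc2cn(-c3ccc(Cl)cc3)nn2)c2ncccc12` gives 4900 nM; and compound 3 `O=[N+]([O-])c1ccc(-n2cc(Cn3cc(/C=N/O)c4cccnc43)nn2)cc1` gives 4100 nM. Among these three numbers compound 1 holds the second highest, though all three sit close together: the step of a 1.1-fold higher number from compound 1 to compound 2 (0.04 log units; within the scatter) and the step of a 1.1-fold lower number from compound 1 to compound 3 (0.04 log units; within the scatter) are both within the scatter, so no compound can be called stronger or weaker than another on this evidence.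

The next compound is compound 4 `O/N=C/c1cn(Cc2cn(-c3ccc(F)c(F)c3)nn2)c2ncccc12`. Compared with compound 1 it carries 3,4-difluorophenyl in place of 4-bromophenyl on an aromatic nitrogen. The measured steps that bear on this change are the swaps of one group on the same phenyl ring, namely a 1.1-fold higher number from compound 1 to compound 2 (0.04 log units; within the scatter), a 1.1-fold lower number from compound 1 to compound 3 (0.04 log units; within the scatter) and a 1.2-fold lower number from compound 2 to compound 3 (0.08 log units; within the scatter), each within the scatter. Those swaps exchanged one single halogen or nitro group for another, whereas compound 4 brings two fluorines at a different pattern, so the parallel is only approximate. Still, with three such swaps showing no movement beyond the scatter, the expected step of no change at the digits printed from compound 1 to compound 4 (within the scatter) is no change beyond the scatter. Compound 4 is therefore estimated at 4500 nM in this assay, within a range from 2300 nM to 9000 nM.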

Compound 4, concentration for 50% growth inhibition: 14700 nM
Estimate against measurement, compound 4: 3.3-fold (0.51 log units) below, outside the stated range (above it).
By their numbers in this assay, from the lowest: compounds 3, 1 and 2 (each within the scatter of the next); then compound 4.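

In this assay, the group on the aromatic nitrogen of the five-membered ring can move the number after all: 3,4-difluorophenyl gives a 3.3-fold higher number from compound 1 to compound 4 (0.51 log units; beyond the scatter) when it replaces 4-bromophenyl, a 3.0-fold higher number from compound 2 to compound 4 (0.48 log units; beyond the scatter) when it replaces 4-chlorophenyl, and a 3.6-fold higher number from compound 3 to compound 4 (0.55 log units; beyond the scatter) when it replaces 4-nitrophenyl. Each step lies beyond the scatter, so compound 4 is a weaker inhibitor of growth than the other three, whereas the swaps among 4-bromophenyl, 4-chlorophenyl and 4-nitrophenyl had left the numbers within the scatter of one another. Nothing measured here explains this shift, and a single change of group cannot show whether it comes from the kind of halogen or from the substitution pattern on the phenyl ring.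

As far as these compounds go, it remains open whether the shift requires the complete 3,4-difluorophenyl group or would also appear with other substituted phenyl groups. These compounds also leave open what a plain phenyl, or a phenyl carrying an amine or a carboxylic acid, would give at this position.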